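Cytotoxicity limits across three amide variants of the core

The source may report more compounds than this note shows. Statements on the series, on what has been measured and on what is new or still open speak of the compounds shown alone.

Measured so far in an ADME assay on Karpas-1106P cells (Homo sapiens) for cytotoxicity; on this read-out lower numbers stand for an effect already at smaller amounts and higher numbers for an effect only at larger amounts of compound:
compound 1 `Cc1ccc(S(=O)(=O)N[C@@H](CC(=O)NC(C)(C)C)C(=O)NCCNC(=O)NCc2ccccc2)cc1` gives > 11100 nM, a limit of the assay rather than a number.
compound 2 `COc1cc(OC)cc(C(=O)NCCNC(=O)[C@H](CC(=O)NC(C)(C)C)NS(=O)(=O)c2ccc(C)cc2)c1` gives > 11100 nM, also a limit.
compound 3 `Cc1ccc(S(=O)(=O)N[C@@H](CC(=O)NC(C)(C)C)C(=O)NCCNC(=O)c2ccc(F)cc2)cc1` gives > 11100 nM, also a limit.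

Compound 1 stands at the limit of > 11100 nM in this assay, at which 3 of the 3 values shown sit, in this assay; no number separates it from the others. Compound 4 `Cc1ccc(S(=O)(=O)N[C@@H](CC(=O)NC(C)(C)C)C(=O)NCCNC(=O)c2ccc(Cl)cc2)cc1` carries the change (4-chlorophenyl in place of benzylamino on a carbonyl carbon). Among the measured compounds shown here, the steps that bear on it are a step that the two limits leave unreadable from compound 1 to compound 3 and a step that the two limits leave unreadable from compound 2 to compound 3, and both are unreadable. Every value sits at the limit. No size or direction can therefore be read in this assay, and nothing beyond the scatter is expected.

Compound 4 is expected to give 15000 nM, within 7000 nM to 40000 nM, most likely reported again as a limit. The expected step is a step that the limit leaves unreadable from compound 1 to compound 4.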

Compound 4, half-maximal effective concentration: > 11100 nM
Compound 4 ended at the assay's limit; the forecaster's own chance of this, stated with the estimate: 85%; the middle value lies beyond the limit too.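

No new step can be read for compound 4 against compounds 1, 2 and 3 in this assay, since all four rest on one limit: the limit of > 11100 nM in this assay, at which 4 of the 4 values shown sit. From the compounds shown here alone, whether these compounds differ at all in this read-out, and in which direction, remains open.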